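Swapping cyclopropyl for dimethylamino on the sulfonyl sulfur

The source may hold more compounds than are shown below. What is called first, only, known or untested is meant among the compounds shown, and "the series" means these compounds.

Measured in a physicochemical assay for solubility, measured as kinetic solubility; on this read-out lower numbers stand for lower solubility and higher numbers for higher solubility:
Compound 1 `CCS(=O)(=O)c1ccc(Oc2cc(C(=O)Nc3cnc(C)cn3)cc3nn(C)cc23)cc1`: 69000 nM
Compound 2 `Cc1cnc(NC(=O)c2cc(Oc3ccc(S(=O)(=O)C4CC4)cc3)c3cn(C)nc3c2)cn1`: 73000 nM

Among the compounds with values here, compound 2, at 73000 nM, stands level with the only other measured compound. The step that links them is a 1.1-fold higher number from compound 1 to compound 2 (0.02 log units; within the scatter), so the two numbers cannot be told apart.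

Compound 3 `Cc1cnc(NC(=O)c2cc(Oc3ccc(S(=O)(=O)N(C)C)cc3)c3cn(C)nc3c2)cn1` keeps the rest of compound 2 and carries dimethylamino in place of cyclopropyl on a sulfonyl sulfur.

Within the data shown here, only one measured step bears on this change, a swap at the same sulfur: a 1.1-fold higher number from compound 1 to compound 2 (0.02 log units; within the scatter). Among the measured compounds shown here, no measured compound has a nitrogen on that sulfur, so the evidence is thin. On this basis, no shift beyond the scatter is expected in this assay.

The expected step is a 1.2-fold lower number from compound 2 to compound 3 (0.07 log units; within the scatter). For compound 3 the estimated value is 62000 nM, with an expected range of 28000 nM to 120000 nM.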

Compound 3, solubility: 134000 nM
Compound 3: middle estimate off by 2.2-fold (0.33 log units), on the low side; the measured number lies above the stated range.
By their numbers in this assay, from the lowest: compounds 1, 2 and 3 (each within the scatter of the next).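

Within the data shown here, on the sulfonyl sulfur, dimethylamino puts a nitrogen where the earlier compounds held only carbon groups, and this assay records a 1.8-fold higher number from compound 2 to compound 3 (0.26 log units; within the scatter) for the swap from cyclopropyl and a 1.9-fold higher number from compound 1 to compound 3 (0.29 log units; within the scatter) for the swap from ethyl. Both steps stay within the scatter, so the three compounds cannot be told apart in this read-out, and the sulfur now carries groups attached through carbon or through nitrogen with no measured shift beyond it. Nothing shown offers a measured reason for the number that compound 3 gives.

Still open, on these data alone, is whether a cyclic amine such as morpholine on the same sulfur, or a simple amine that keeps a hydrogen on its nitrogen, would also stay within the scatter. A longer chain on the nitrogen, such as diethylamino, is equally untested in the compounds shown here.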